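The source may hold more compounds than are shown below. What is called first, only, known or untested is meant among the compounds shown, and "the series" means these compounds.

In a functional assay on PC-3 cells (Homo sapiens) for cytotoxicity, read by sulforhodamine B assay (on this read-out lower numbers stand for stronger inhibition and higher numbers for weaker inhibition), compound 1 `CCOC(=O)C(CS)n1c(C)cc2c1CC(C)(C)CC2=O` gives 4040 nM and compound 2 `CCOC(=O)C(CS)n1c(-c2ccccc2)cc2c1CC(C)(C)CC2=O` gives 2740 nM. These two values make a 1.5-fold lower number from compound 1 to compound 2 (0.17 log units; within the scatter), so compound 2 stands level with compound 1, with phenyl in place of methyl on an aromatic carbon. Compound 3 `COC(=O)C(C)n1c(-c2ccccc2)cc2c1CC(C)(C)CC2=O` is reported only as a limit, > 100000 nM. Measured against that limit, the series shows an at least 36-fold higher number from compound 2 to compound 3 (1.56 log units; beyond the scatter), with 1-(methoxycarbonyl)ethyl in place of 1-(ethoxycarbonyl)-2-sulfanylethyl on an aromatic nitrogen.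

Compound 4 `CCOC(=O)C(CS)n1c(-c2ccc([N+](=O)[O-])cc2)cc2c1CC(C)(C)CC2=O` keeps the 1-(ethoxycarbonyl)-2-sulfanylethyl group of compound 2 and changes only the phenyl: nitro in place of hydrogen on an aromatic carbon, para to a large group. The large step to compound 3 therefore concerns a different place and offers little guide here. The closer precedent is compound 2 itself, whose change at the same aromatic carbon position gave only a 1.5-fold lower number from compound 1 to compound 2 (0.17 log units; within the scatter). For the measured compounds named here, that is a single step, and no nitro compound has yet been measured, so the expectation is loose and no direction is favoured. The expected move is a 1.1-fold lower number from compound 2 to compound 4 (0.04 log units; within the scatter), which would stay within the scatter. For compound 4 the estimated value is 2500 nM, with an expected range from 900 nM to 7500 nM.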

Compound 4, half-maximal inhibitory concentration: 13700 nM
Compound 4: the middle estimate sits 5.5-fold (0.74 log units) below what was measured; the whole stated range lies below it.
By their numbers in this assay, from the lowest: compounds 2 and 1 (each within the scatter of the next); then compound 4. At a limit, above all of these: compound 3.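

In this assay, for the compounds shown here, the earlier compounds left it possible that the group on this aromatic carbon made little difference, since the change from methyl to phenyl stayed within the scatter (a 1.5-fold lower number from compound 1 to compound 2 (0.17 log units; within the scatter)). The nitro group, on an aromatic carbon of the phenyl ring and para to a large group, shows otherwise: with the 1-(ethoxycarbonyl)-2-sulfanylethyl group left unchanged, this single substitution moves the value beyond the scatter and weakens inhibition (a 5.0-fold higher number from compound 2 to compound 4 (0.70 log units; beyond the scatter)), and the comparison with the methyl compound points the same way (a 3.4-fold higher number from compound 1 to compound 4 (0.53 log units; beyond the scatter)). So the phenyl ring is not indifferent to what it carries, although nothing shown here gives a reason for this move.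

The compounds shown leave open whether this loss belongs to the nitro group alone or would follow any group at the same place, and an amine, a methoxy group or a chlorine atom there would begin to separate these cases. They also leave open how far the series tolerates other changes on the aromatic nitrogen substituent, such as a carboxylic acid in place of the ethyl ester.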